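The compounds below may be only part of what the source reports. "The series", "measured", "known", "first", "only" and "open" are said of these compounds alone.

In a functional assay on HT-29 cells (Homo sapiens) for inhibition, read by sulforhodamine B assay, with a stated time of 48 h (on this read-out higher numbers stand for weaker inhibition of growth and lower numbers for stronger inhibition of growth), compound 1 (`c1cc(C2CCCCC2)ccc1NC1=NCCO1`) gives 12800 nM and so sits in the middle of the three measured compounds. Compound 2 (`c1cc(NC2=NCCO2)cc(OC2CCCC2)c1`) reads 52200 nM on the higher side of it, and compound 3 (`c1ccc(COc2cccc(NC3=NCCO3)c2)cc1`) reads 800 nM on the lower side. The compound still to be measured, compound 4 (`Cc1ccc(NC2=NCCO2)cc1`), keeps the core of compound 1 but carries methyl in place of cyclohexyl on an aromatic carbon. Among the measured compounds shown here, no two measured compounds differ in one place only, so the data give no direct size for such a change. All three measured compounds carry a group containing a ring, and none has a group as small as methyl, so this step leads outside what has been tested. A step towards a higher number, meaning weaker inhibition of growth and lying beyond the usual scatter, is expected, though with wide uncertainty. This expectation rests on compound 1 at 12800 nM giving up most of its group. In numbers, the expected change is a 3.1-fold higher number from compound 1 to compound 4 (0.49 log units; beyond the scatter) in this estimate. Compound 4 is estimated at 40000 nM with an expected range from 12000 nM to 130000 nM as a working guess.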

Compound 4, concentration for 50% growth inhibition: 13000 nM
Beside the measured number, compound 4's estimate is 3.1-fold (0.49 log units) above it; the range from low to high includes it.
By their numbers in this assay, from the lowest: compound 3; then compounds 1 and 4 (each within the scatter of the next); then compound 2.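

In this assay, putting methyl in place of cyclohexyl on an aromatic carbon gives a 1.0-fold higher number from compound 1 to compound 4 (0.01 log units; within the scatter). This is the only step shown at this position, and it reveals what the earlier compounds could not: a group of 6 heavy atoms containing a six-membered non-aromatic ring and a group of 1 heavy atom with no ring give readings that cannot be told apart, so for this pair the ring is not needed for the level of growth inhibition seen. Nothing available explains why the two compounds read alike.

Only these two groups have been compared at this position, so the result cannot say whether a plain hydrogen, a longer chain such as butyl, an amine or a carboxylic acid would read the same. Compound 2 and compound 3 each differ from compound 4 in more than one place, so they leave open whether the same swap would give a similar result in another setting.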